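This account rests on a few compounds, and the source may have more. Where it says the series, first, only, none or still open, it means among the compounds named here.

Measured so far in a functional assay on NALM-6 cells (Homo sapiens) for cytotoxicity, read by MTT assay, with a stated time of 48 h; a higher number here means a weaker inhibitor, a lower number a stronger inhibitor:
- compound 1 `CCN(CC)c1ccc(C(F)(F)F)cc1NC(=O)c1cccnc1`: 63200 nM
- compound 2 `O=C(Nc1cc(C(F)(F)F)ccc1N1CCCC1)c1ccncc1`: "not active" (no number reported)

Going by the values given here, compound 2 stands without a value in this assay; only the report of inactivity is available, so no step from it can be sized. Compound 3 `O=C(Nc1cc(C(F)(F)F)ccc1N1CCCC1)c1cccnc1` carries pyridin-3-yl in place of pyridin-4-yl on a carbonyl carbon. Compound 1, which also holds pyridin-3-yl on the carbonyl carbon, gives a weak number in this assay, and compound 3 is expected to land near it, though inactivity remains a fair chance. For compound 3 the estimate in this assay is 60000 nM, range 15000 nM to 200000 nM.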

Compound 3, half-maximal inhibitory concentration: "not active" (no number reported)
No number was reported for compound 3; the estimate stays without a comparison.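

Compound 2 and compound 3 are both reported as not active in this assay and no step can be read between them. The compounds shown leave open whether swapping pyridin-4-yl for pyridin-3-yl on the carbonyl carbon changes cytotoxicity at all. No evidence bears on this result.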